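Exchanging the furan side group for a pyridinylamino chain

The source may report more compounds than this note shows. Statements on the series, on what has been measured and on what is new or still open speak of the compounds shown alone.

In an assay on CHO cells for displacement of a labelled ligand from 5-hydroxytryptamine receptor 1D (Homo sapiens) (a higher number here means a weaker inhibitor, a lower number a stronger inhibitor), compound 1 `c1cc(CNC2CCN(CCCc3c[nH]c4ccc(-n5cnnc5)cc34)CC2)co1` gives 4.5 nM, while compound 2 `CN(Cc1ccco1)C1CCN(CCCc2c[nH]c3ccc(-n4cnnc4)cc23)CC1` gives 9.3 nM, the highest of the two numbers, reached by a 2.1-fold higher number from compound 1 to compound 2 (0.32 log units; beyond the scatter). Compound 3 `c1ccc(NCC2CCN(CCCc3c[nH]c4ccc(-n5cnnc5)cc34)CC2)nc1` differs from compound 2 by ((pyridin-2-yl)amino)methyl in place of ((furan-2-yl)methyl)(methyl)amino on a saturated ring carbon. Among the compounds with values here, the only measured step touches the same saturated ring carbon and was modest, and no step shows the entering group itself, so a step of similar size in this assay, in either direction, is expected for compound 3, as a 1.2-fold lower number from compound 2 to compound 3 (0.07 log units; within the scatter). Compound 3 is estimated at 8 nM, within 2.5 nM to 25 nM.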

Compound 3, half-maximal inhibitory concentration: 1.7 nM
Compound 3: the middle estimate sits 4.7-fold (0.67 log units) above what was measured; the whole stated range lies above it.
By their numbers in this assay, from the lowest: compound 3; then compound 1; then compound 2.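

In this assay, within the data shown here, the saturated ring carbon turns out to allow a larger gain than the one earlier step suggested: ((pyridin-2-yl)amino)methyl gives a 5.5-fold lower number from compound 2 to compound 3 (0.74 log units; beyond the scatter) and a 2.6-fold lower number from compound 1 to compound 3 (0.42 log units; beyond the scatter). Compound 3 thus has the lowest number of the three, with its steps to both furan compounds beyond the scatter. Nothing available explains this gain. From the compounds shown here alone, the change replaces the ring and its link to the saturated ring together, so which part carries the step remains open. Whether a phenyl ring could stand in for the pyridin-2-yl ring, or a methyl group on the linking amine would be tolerated, is also unresolved.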